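The source may report more compounds than this note shows. Statements on the series, on what has been measured and on what is new or still open speak of the compounds shown alone.

Of the compounds shown here, three with a shared core have been tested in a functional assay on HCT-116 cells (Homo sapiens) for antiproliferative activity, read by MTT assay, with a stated time of 24 h; a higher number here means a weaker inhibitor, a lower number a stronger inhibitor. In this assay compound 1 `COc1ccc(C(=O)/C=C/c2ccc([N+](=O)[O-])cc2)c2c1C=CC(C)(C)O2`, which carries 4-nitrophenyl, gives 8880 nM. Compound 2 `COc1ccc(C(=O)/C=C/c2ccco2)c2c1C=CC(C)(C)O2`, which carries furan-2-yl, is reported only as a limit, > 10000 nM. Compound 3 `COc1ccc(C(=O)/C=C/c2cccc(Cl)c2)c2c1C=CC(C)(C)O2`, which carries 3-chlorophenyl, is also reported only as a limit, > 10000 nM. Compound 3 therefore has no number of its own and stands at the limit of > 10000 nM in this assay, at which 2 of the 3 values shown sit.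

Compound 4 `COc1ccc(C(=O)/C=C/c2ccccc2Cl)c2c1C=CC(C)(C)O2` has not yet been measured. It differs from compound 3 in one group: 2-chlorophenyl in place of 3-chlorophenyl on a double-bonded chain carbon bound to a double-bonded chain carbon. It has 2-chlorophenyl in place of 3-chlorophenyl, on a double-bonded chain carbon bound to a double-bonded chain carbon.

For the measured compounds named here, no measured step makes this exact exchange, but three touch the same place. Replacing 4-nitrophenyl with 3-chlorophenyl gives an at least 1.1-fold higher number from compound 1 to compound 3 (0.05 log units; that floor lies within the scatter). Replacing it with furan-2-yl gives an at least 1.1-fold higher number from compound 1 to compound 2 (0.05 log units; that floor lies within the scatter). Both sizes are only floors. The third exchange gives a step that the two limits leave unreadable from compound 2 to compound 3.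

On the floor of an at least 1.1-fold higher number from compound 1 to compound 3 (0.05 log units; that floor lies within the scatter), no step beyond the scatter is expected in this assay, and a further report as a limit is likely. The expected change is a step that the limit leaves unreadable from compound 3 to compound 4. For compound 4 the estimated value is 12000 nM, with an expected range from 6000 nM to 25000 nM.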

Compound 4, half-maximal inhibitory concentration: > 10000 nM
Compound 4 ended at the assay's limit; the forecaster's own chance of this, stated with the estimate: 70%; the middle value lies beyond the limit too.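

In this assay, for the compounds shown here, the exchange of 3-chlorophenyl for 2-chlorophenyl on a double-bonded chain carbon bound to a double-bonded chain carbon yields no readable number, so moving the chlorine from one ring position to the other shows no measurable gain at this limit; this step and the one from compound 2 to compound 4 cannot be read. Going by these compounds alone, the one readable step is an at least 1.1-fold higher number from compound 1 to compound 4 (0.05 log units; that floor lies within the scatter) and, like the floor already seen for compound 3, it shows no separation from compound 1 beyond the scatter. This place has now carried furan-2-yl and two chlorophenyl groups that all end at the same limit: the limit of > 10000 nM in this assay, at which 3 of the 4 values shown sit.

From the compounds shown here alone, the limits hide any difference among compound 2, compound 3 and compound 4, so it remains open how far each lies from the others or from compound 1. Going by these compounds, it also remains open whether a phenyl ring carrying an amine or a carboxylic acid at this place would give a number well inside the range of the assay.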